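Para-substituent swap on the benzyl arm: nitro to fluoro

A few compounds are considered here, and "the series" means these few. Any claim that something is new, unique, unknown or untested is made for them only; others in the source may bear on it.

Measured so far:
- compound 1, `CCCN(Cc1ccc(Cl)cc1)Cc1c(C(F)(F)F)nc2n(-c3c(C)cc(C)cc3C)c(Cl)cn12`: 28 nM
- compound 2, `CCCN(Cc1ccc([N+](=O)[O-])cc1)Cc1c(C(F)(F)F)nc2n(-c3c(C)cc(C)cc3C)c(Cl)cn12`: 150 nM

In an assay on cells for displacement of a labelled ligand from corticotropin-releasing factor receptor 1 (Homo sapiens), with a stated time of 100 min (on this read-out lower numbers stand for stronger inhibition and higher numbers for weaker inhibition), compound 2 gives the higher of the two numbers recorded; its nearest neighbour is compound 1, and the gap between them is a 5.4-fold higher number from compound 1 to compound 2 (0.73 log units; beyond the scatter), a change of nitro in place of chloro on an aromatic carbon.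

Compound 3, `CCCN(Cc1ccc(F)cc1)Cc1c(C(F)(F)F)nc2n(-c3c(C)cc(C)cc3C)c(Cl)cn12`, is not yet measured. It differs from compound 2 by fluoro in place of nitro on an aromatic carbon, para to a large group on the six-membered carbon-only ring. For the measured compounds named here, the only measured step that bears on this position is a 5.4-fold higher number from compound 1 to compound 2 (0.73 log units; beyond the scatter), where removing the halogen in favour of nitro raised the number beyond the scatter. Returning to a halogen, fluoro, is therefore expected to move the number back toward that of compound 1, giving an expected step of a 3.8-fold lower number from compound 2 to compound 3 (0.57 log units; beyond the scatter). Compound 3 is expected to give 40 nM in this assay, in the range 15 nM to 110 nM.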

Compound 3, inhibition constant: 350 nM
Beside the measured number, compound 3's estimate is 8.8-fold (0.94 log units) below it; measured number outside the range, above it.
By their numbers in this assay, from the lowest: compound 1; then compound 2; then compound 3.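

In this assay, the two halogens are not interchangeable at this position: the change from chloro to fluoro gives the largest step in the set (a 13-fold higher number from compound 1 to compound 3 (1.10 log units; beyond the scatter)). Fluoro also does not recover the loss seen with nitro (a 2.3-fold higher number from compound 2 to compound 3 (0.37 log units; beyond the scatter)), so among these three compounds, a return to a halogen does not by itself give a lower number, and chloro alone gives the lowest. No measurement here accounts for this order.

On these data alone, whether the low number is particular to chloro or extends to bromo, methyl or methoxy at this position remains open. Also open, as far as these compounds go, is how the unsubstituted benzyl arm compares with these three compounds, and whether the same order holds with a longer chain in place of the propyl group.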